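This account rests on a few compounds, and the source may have more. Where it says the series, first, only, none or still open, it means among the compounds named here.

Compound 1 `CC(O)c1cn(CCNc2nonc2/C(=N/O)Nc2ccc(F)c(Br)c2)nn1` gives 362 nM in an assay on isolated protein for inhibition of Indoleamine 2,3-dioxygenase 2 (Homo sapiens); on this read-out higher numbers stand for weaker inhibition and lower numbers for stronger inhibition. Compound 2 `CCC(O)c1cn(CCNc2nonc2/C(=N/O)Nc2ccc(F)c(Br)c2)nn1` gives 947 nM in this assay; the change methyl in place of hydrogen on a saturated chain carbon, two bonds along the chain from an aromatic carbon and an oxygen on a saturated carbon made the step of a 2.6-fold higher number from compound 1 to compound 2 (0.42 log units; beyond the scatter). Compound 3 `OCCOCc1cn(CCNc2nonc2/C(=N/O)Nc2ccc(F)c(Br)c2)nn1` gives 144 nM in this assay and differs from compound 1 in its core by (2-hydroxyethoxy)methyl in place of 1-hydroxyethyl on an aromatic carbon, the step being a 2.5-fold lower number from compound 1 to compound 3 (0.40 log units; beyond the scatter). Compound 4 `CC(OCCO)c1cn(CCNc2nonc2/C(=N/O)Nc2ccc(F)c(Br)c2)nn1` is not yet measured; it carries methyl in place of hydrogen on a saturated chain carbon bound to an aromatic carbon and an oxygen on a saturated carbon. This is the same kind of change as that from compound 1 to compound 2, but its place differs: here the methyl sits on a saturated chain carbon bound to an aromatic carbon and an oxygen on a saturated carbon, whereas before it sat two bonds along the chain from these. Resting on the step of a 2.6-fold higher number from compound 1 to compound 2 (0.42 log units; beyond the scatter), compound 4 is expected to show a similar rise, a 2.5-fold higher number from compound 3 to compound 4 (0.40 log units; beyond the scatter). Compound 4 is estimated at 360 nM, between 160 nM and 850 nM.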

Compound 4, half-maximal inhibitory concentration: 930 nM
Estimate against measurement, compound 4: 2.6-fold (0.41 log units) below, outside the stated range (above it).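

In this assay, the added methyl gave a higher number on both cores, and the two steps do not differ beyond the scatter: the same change on two cores in this assay, a 2.6-fold higher number (0.42 log units; beyond the scatter) from compound 1 to compound 2 and a 6.5-fold higher number (0.81 log units; beyond the scatter) from compound 3 to compound 4, 2.5-fold (0.39 log units) apart, within the scatter of two such steps. The new step is a 6.5-fold higher number from compound 3 to compound 4 (0.81 log units; beyond the scatter), so the change carried over in direction, but two pairs do not show that its size is fixed or that it would hold on any other core. The remaining steps read a 2.6-fold higher number from compound 1 to compound 4 (0.41 log units; beyond the scatter), with 2-hydroxyethyl in place of hydrogen on the oxygen, and a 1.0-fold lower number from compound 2 to compound 4 (0.01 log units; within the scatter), so 1-(2-hydroxyethoxy)ethyl and 1-hydroxypropyl cannot be told apart here. The compounds shown leave open how an ethyl or an amine in place of that hydrogen on the saturated chain carbon would read.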